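Nitro in place of chloro on the shared core

This account rests on a few compounds, and the source may have more. Where it says the series, first, only, none or still open, it means among the compounds named here.

Compound 1 `O=C(NCCCCc1ccccc1)n1c(=O)oc2ccc(Cl)cc21` gives 15 nM in an assay on HEK293 cells for inhibition of acid ceramidase (Homo sapiens), with a stated time of 10 min; on this read-out higher numbers stand for weaker inhibition and lower numbers for stronger inhibition.
Compound 2 `O=C(NCCCCc1ccccc1)n1c(=O)oc2cc([N+](=O)[O-])ccc21` gives 3 nM in this assay.
Compound 3 `O=C(NCCCCc1ccccc1)n1c(=O)oc2cc(Cl)ccc21` gives 33 nM in this assay.

Compound 1 and compound 3 are built from the same atoms joined differently; the difference between the two cores is not broken down here. Of the three numbers in this assay compound 1 stands second highest: compound 3 gives a higher number and compound 2 a lower one, both gaps beyond the scatter.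

For the measured compounds named here, the one single-point change measured so far is nitro in place of chloro on an aromatic carbon, which gave an 11-fold lower number from compound 3 to compound 2 (1.04 log units; beyond the scatter).

Compound 4 `O=C(NCCCCc1ccccc1)n1c(=O)oc2ccc([N+](=O)[O-])cc21` carries the same change on the core of compound 1: nitro in place of chloro on an aromatic carbon. The surroundings of the place are described in the same words for both pairs, so this is taken as the same change, not merely the same kind.

For compound 4 the step from compound 1 is expected to be a 7.5-fold lower number from compound 1 to compound 4 (0.88 log units; beyond the scatter), resting on the step of an 11-fold lower number from compound 3 to compound 2 (1.04 log units; beyond the scatter) applied to the value of compound 1 in this assay, 15 nM. With only one earlier occurrence of the change to go on, the step is expected to carry over in direction and roughly in size, though a somewhat smaller step is allowed for in the range.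

For compound 4 the value in this assay is estimated at 2 nM, expected to lie between 0.7 nM and 6 nM.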

Compound 4, half-maximal inhibitory concentration: 3 nM
Estimate against measurement, compound 4: 1.5-fold (0.18 log units) below; the measured number falls inside the stated range.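

Nitro in place of chloro on an aromatic carbon lowers the number on both cores in this assay, and the new case is a 5.0-fold lower number from compound 1 to compound 4 (0.70 log units; beyond the scatter). Set beside the earlier case, the two steps run in the same direction and cannot be told apart in size: the same change on two cores in this assay, an 11-fold lower number (1.04 log units; beyond the scatter) from compound 3 to compound 2 and a 5.0-fold lower number (0.70 log units; beyond the scatter) from compound 1 to compound 4, 2.2-fold (0.34 log units) apart, within the scatter of two such steps. In this assay the change therefore carries from one of these cores to the other, but two pairs say nothing about other cores or other read-outs, and they give no explanation of why the number falls.

The compounds shown leave open whether other groups at this place, such as an amine, a nitrile or a carboxylic acid, would fall on the nitro side or the chloro side of these steps. Going by these compounds, the chain ending in the phenyl ring is the same in all four compounds, so it also remains open whether the step from chloro to nitro keeps its direction and size with a shorter or longer chain.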